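From tert-butoxycarbonyl to methyl on a ring nitrogen

The source may report more compounds than this note shows. Statements on the series, on what has been measured and on what is new or still open speak of the compounds shown alone.

In a functional assay on HepG2 cells (Homo sapiens) for cytotoxicity, read by MTT assay, with a stated time of 48 h (on this read-out higher numbers stand for weaker inhibition and lower numbers for stronger inhibition), compound 1 `CCN(CC)CC(=O)N1N=C(C)CC1c1ccccc1O` gives 51600 nM and compound 2 `CC1=NN(C(=O)CN2CCCCC2)C(c2ccccc2O)C1` gives 3020 nM on the same scale. Compound 3 `CC1=NN(C(=O)CN2CCN(C(=O)OC(C)(C)C)CC2)C(c2ccccc2O)C1` reads 5000 nM here, within the scatter of compound 2 and far under compound 1. Compound 4 `CC1=NN(C(=O)CN2CCN(C)CC2)C(c2ccccc2O)C1` differs from compound 3 in one place, and the change is methyl in place of tert-butoxycarbonyl on an amine nitrogen in a ring with methyl in place of tert-butoxycarbonyl on an amine nitrogen in a ring. Within the data shown here, the only measured step, a 17-fold lower number from compound 1 to compound 2 (1.23 log units; beyond the scatter) and large, swapped diethylamino for piperidin-1-yl, so it bears only loosely on this change. The expected result is a 1.2-fold higher number from compound 3 to compound 4 (0.08 log units; within the scatter) and so nothing beyond the scatter in this assay for this swap. Compound 4 is estimated at 6000 nM with an expected range from 2000 nM to 20000 nM around that middle.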

Compound 4, half-maximal inhibitory concentration: "not active" (no number reported)
Compound 4 has no reported number here; the estimate stays without a comparison.
By their numbers in this assay, from the lowest: compounds 2 and 3 (each within the scatter of the next); then compound 1.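

Among these compounds, compound 4 is reported as "not active" in this assay without a number, so no step from compound 3 to compound 4 can be read. From the compounds shown here alone, what methyl in place of tert-butoxycarbonyl does to the number stays open, and no other data here bear on this result.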